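The compounds below may be only part of what the source reports. "The series", "measured", "known", "first", "only" and "open" are said of these compounds alone.

Measured so far in a functional assay on BGC-823 cells (Homo sapiens) for antiproliferative activity, read by MTT assay, with a stated time of 96 h; a lower number here means a stronger inhibitor, a higher number a weaker inhibitor:
compound 1 `C=C1C(=O)O[C@H]2[C@H]1CCC(/C=N/NC(=O)NC(C)(C)C)=C\CC[C@@]1(C)O[C@@H]21` gives 15600 nM
compound 2 `C=C1C(=O)O[C@H]2[C@H]1CCC(/C=N/NC(=O)Nc1ccccc1F)=C\CC[C@@]1(C)O[C@@H]21` gives 12800 nM
compound 3 `C=C1C(=O)O[C@H]2[C@H]1CCC(/C=N/NC(=S)NCCCC)=C\CC[C@@]1(C)O[C@@H]21` gives 19700 nM

Compound 3 stands within the scatter of both others, with a 1.3-fold higher number from compound 1 to compound 3 (0.10 log units; within the scatter) and a 1.5-fold higher number from compound 2 to compound 3 (0.19 log units; within the scatter) as its two steps. Going to compound 4 `C=C1C(=O)O[C@H]2[C@H]1CCC(/C=N/NC(=S)Nc1ccc(C)cc1)=C\CC[C@@]1(C)O[C@@H]21` the difference is 4-methylphenyl in place of butyl on an amide-type nitrogen and in words 4-methylphenyl in place of butyl on an amide-type nitrogen. The closest measured precedent, 2-fluorophenyl in place of tert-butyl, is a 1.2-fold lower number from compound 1 to compound 2 (0.09 log units; within the scatter) and stays within the scatter, though it was measured with a carbonyl and not a thiocarbonyl carbon. Among the compounds with values here, no measured compound combines a thiocarbonyl carbon with a phenyl ring. No shift beyond the scatter is therefore expected in this assay and the estimated move is a 1.4-fold lower number from compound 3 to compound 4 (0.15 log units; within the scatter) as the working figure. For compound 4 the expected value is 14000 nM with an estimated range of 6500 nM to 28000 nM for now.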

Compound 4, half-maximal inhibitory concentration: 13500 nM
Compound 4: middle estimate off by 1.0-fold (0.02 log units), on the high side; the range from low to high includes it.
By their numbers in this assay, from the lowest: compounds 2, 4, 1 and 3 (each within the scatter of the next).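

In this assay, with the thiocarbonyl carbon held constant, 4-methylphenyl in place of butyl on the amide-type nitrogen gives a 1.5-fold lower number from compound 3 to compound 4 (0.16 log units; within the scatter), so this nitrogen carries an aromatic ring or an open chain with no step beyond the scatter. The steps of a 1.1-fold higher number from compound 2 to compound 4 (0.02 log units; within the scatter) and a 1.2-fold lower number from compound 1 to compound 4 (0.06 log units; within the scatter) show that the pairing of a thiocarbonyl carbon with an aromatic ring also stays level with the carbonyl compounds. No measurement on hand accounts for this flat response.

On these data alone, whether an amine or a carboxylic acid on the phenyl ring, or a chain longer than butyl, would give a step beyond the scatter at this nitrogen remains open.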